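Moving the methoxy group around the anilino ring

The source may hold more compounds than are shown below. What is called first, only, known or untested is meant among the compounds shown, and "the series" means these compounds.

Of the compounds shown here, two have been tested in a functional assay on MGC-803 cells (Homo sapiens) for inhibition, read by sulforhodamine B assay; on this read-out lower numbers stand for stronger inhibition and higher numbers for weaker inhibition. Compound 1 `O=C1C=C(Nc2ccccc2F)C(=O)c2c1nc1n2[C@H]2OC[C@@H](O)[C@H]2OC1` gives 2080 nM. Compound 2 `COc1ccccc1NC1=CC(=O)c2nc3n(c2C1=O)[C@H]1OC[C@@H](O)[C@H]1OC3` gives 1630 nM; the difference between them, a methoxy in place of fluoro on an aromatic carbon, amounts to a 1.3-fold lower number from compound 1 to compound 2 (0.11 log units; within the scatter), so the two stand at indistinguishable level and neither can be called the more active.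

Compound 3 `COc1cccc(NC2=CC(=O)c3nc4n(c3C2=O)[C@H]2OC[C@@H](O)[C@H]2OC4)c1` has not yet been measured. It differs from compound 2 by 3-methoxyphenyl in place of 2-methoxyphenyl on an amine nitrogen. Among the measured compounds shown here, no measured step addresses such a shift of the same group around the ring; the only step known, the exchange of fluoro for methoxy, stayed within the scatter, and it offers no direction for the present change. The expectation for compound 3 in this assay is therefore a step of a 1.0-fold lower number from compound 2 to compound 3 (0.01 log units; within the scatter), nothing beyond the scatter. Compound 3 is estimated at 1600 nM, with a range from 700 nM to 3600 nM.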

Compound 3, half-maximal inhibitory concentration: 1780 nM
Compound 3: the middle estimate sits 1.1-fold (0.05 log units) below what was measured, and the stated range covers the measured number.
By their numbers in this assay, from the lowest: compounds 2, 3 and 1 (each within the scatter of the next).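

In this assay, moving the methoxy group, with 3-methoxyphenyl in place of 2-methoxyphenyl on the amine nitrogen, gives a 1.1-fold higher number from compound 2 to compound 3 (0.04 log units; within the scatter). Unlike the earlier exchange of fluoro for methoxy, this change keeps the same atoms and alters only how they are joined, so it shows that these two placings of the methoxy group cannot be told apart on this read-out. The step that alters both the group and its placing, a 1.2-fold lower number from compound 1 to compound 3 (0.07 log units; within the scatter), stays within the scatter too, so compounds 1, 2 and 3 stand at one level, and no measurement is at hand that would account for this.

As far as these compounds go, whether a larger departure on the same ring, such as a carboxylic acid or a dimethylamino group, would carry the number beyond the scatter remains open. So does whether a plain alkyl chain in place of the aromatic ring on the amine nitrogen would keep the level seen with these three compounds.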